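The source may report more compounds than this note shows. Statements on the series, on what has been measured and on what is new or still open speak of the compounds shown alone.

Of the compounds shown here, three have been measured in a functional assay on DU-145 cells (Homo sapiens) for inhibition, read by trypan blue exclusion, with a stated time of 96 h; on this read-out higher numbers stand for weaker inhibition of growth and lower numbers for stronger inhibition of growth. Compound 1 `Cc1ccc(S/C(=C/c2c(O)cc(O)cc2O)C(=O)c2ccc(Cl)cc2)cc1` gives only a limit in this assay, > 100000 nM. Compound 2 `O=C(/C(=C\c1c(O)cc(O)cc1O)Sc1ccccc1Br)c1ccc(Cl)cc1` likewise gives only a limit, > 100000 nM. The change between them is 2-bromophenyl in place of 4-methylphenyl on a sulfur and the step is a step that the two limits leave unreadable from compound 1 to compound 2; since both values sit at the limit of > 100000 nM in this assay, at which 2 of the 3 values shown sit, its size cannot be read. Among the compounds with values here, compound 3 `Cc1ccc(S(=O)(=O)/C(=C/c2ccc(Br)cc2)C(=O)c2ccc(Br)cc2)cc1` is the one compound with a number: in this assay compound 3 gives 10000 nM. The difference between the core of compound 1 and the core of compound 3 is not broken down here.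

Compound 4 `O=C(/C(=C\c1ccc(Br)cc1)S(=O)(=O)c1ccccc1Br)c1ccc(Br)cc1` has not been measured. It differs from compound 3 by 2-bromophenyl in place of 4-methylphenyl on a sulfonyl sulfur, the same kind of change as in the earlier pair, though the place differs: in the earlier pair the change sits on a sulfur whose other neighbours are a double-bonded chain carbon, whereas here it sits on a sulfonyl sulfur whose other neighbours are a double-bonded chain carbon. The earlier step offers no readable size, so the step is estimated as no change at the digits printed from compound 3 to compound 4 (within the scatter), essentially flat. Compound 4 is therefore expected to give 10000 nM in this assay, with a range from 3000 nM to 50000 nM.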

Compound 4, concentration for 50% growth inhibition: 1000 nM
The estimate for compound 4 lay 10-fold (1.00 log units) above the measured number; measured number below the stated range.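

In this assay there is a 10-fold lower number from compound 3 to compound 4 (1.00 log units; beyond the scatter) when 2-bromophenyl stands in place of 4-methylphenyl on a sulfonyl sulfur, so on the core of compound 3 this change goes with stronger inhibition of growth. This is a single pair on a single core, and it does not show that the change carries over to another core. The same change on the core of compound 1 gives no readable step, as both of its values are limits and not numbers: the limit of > 100000 nM in this assay, at which 2 of the 4 values shown sit.

The compounds shown leave open whether a phenyl carrying an amine or a carboxylic acid, or a plain ethyl chain, would do the same on the sulfonyl sulfur. They also leave open which of the differences between the core of compound 1 and the core of compound 3 matters for inhibition of growth in this assay.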